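The compounds below may be only part of what the source reports. "The series", "measured", "known", "first", "only" and "open" are said of these compounds alone.

Measured so far in an assay on membranes from CHO cells for displacement of a labelled ligand from adenosine receptor A1 (Homo sapiens), read by scintillation counting, with a stated time of 60 min, tested at 1 uM; a lower number here means less inhibition, a higher number more inhibition at the concentration tested (going by the name of the read-out): compound 1 `CCSC(=O)C1=C(C)NC(=O)NC1c1ccco1` gives 6%, compound 2 `CC1=C(C(=O)SC(C)C)C(c2ccco2)NC(=O)N1` gives 5%, and compound 3 `CCSC(=O)C1=C(C)NC(=O)NC1c1ccoc1` gives 3%.

Compound 2 differs from compound 1 by methyl in place of hydrogen on a saturated chain carbon bound to a saturated chain carbon and a sulfur, a change that gave a number 1 percentage points lower from compound 1 to compound 2 (within the scatter). Compound 3 differs from compound 1 in its core by furan-3-yl in place of furan-2-yl on a saturated ring carbon, which gave a number 3 percentage points lower from compound 1 to compound 3 (within the scatter). All three numbers are low and lie within the scatter of one another, so no order can be read among them.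

Compound 4 `CC1=C(C(=O)SC(C)C)C(c2ccoc2)NC(=O)N1` has not yet been measured. It differs from compound 3 by methyl in place of hydrogen on a saturated chain carbon bound to a saturated chain carbon and a sulfur, the same change, at the same place, as from compound 1 to compound 2. Because that earlier step was a number 1 percentage points lower from compound 1 to compound 2 (within the scatter), compound 4 is expected to stay at a similarly low level. The expected step is no change at the digits printed from compound 3 to compound 4 (within the scatter). Compound 4 is thus estimated at 3% in this assay, most likely between -5% and 12%.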

Compound 4, a percentage reported as inhibition, at one concentration (the size of the read-out at that concentration, not a potency): 9%
The estimate for compound 4 lay 6 percentage points below the measured number; low and high end bracket the measured number.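

In this assay, the change from ethylsulfanyl to isopropylsulfanyl, with furan-3-yl on the core, gave a number 6 percentage points higher from compound 3 to compound 4 (within the scatter), and the change from furan-2-yl to furan-3-yl, with isopropylsulfanyl in place, gave a number 4 percentage points higher from compound 2 to compound 4 (within the scatter). The ethyl to isopropyl change cannot be told apart on the two cores: the same change on two cores in this assay, a number 1 percentage points lower (within the scatter) from compound 1 to compound 2 and a number 6 percentage points higher (within the scatter) from compound 3 to compound 4, 7 percentage points apart, within the scatter of two such steps. The same holds for the furan change, yet with every step inside the scatter this shows no effect carried from one core to another, only that no effect can be read on either: the same change on two cores in this assay, a number 3 percentage points lower (within the scatter) from compound 1 to compound 3 and a number 4 percentage points higher (within the scatter) from compound 2 to compound 4, 7 percentage points apart, within the scatter of two such steps.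

The compounds shown leave open whether a longer chain in place of ethyl, or an amine on that chain, would give a number clear of the scatter. The same question stands for a phenyl ring in place of the furan.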